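Swapping the Aryl Group on the Shared Core

The source may report more compounds than this note shows. Statements on the series, on what has been measured and on what is new or still open speak of the compounds shown alone.

Compound 1 `Cc1ccc(S(=O)(=O)NCc2cn(C[C@H](O)[C@H]3OC(=O)C(OCc4ccccc4)=C3OCc3ccccc3)nn2)cc1`: 24900 nM
Compound 2 `COc1ccccc1-c1cn(C[C@H](O)[C@H]2OC(=O)C(OCc3ccccc3)=C2OCc2ccccc2)nn1`: a limit only, > 100000 nM

In a functional assay on HepG2 cells (Homo sapiens) for antiproliferative activity, read by MTT assay, with a stated time of 72 h (a higher number here means a weaker inhibitor, a lower number a stronger inhibitor), compound 1 gives 24900 nM. Compound 2 in this assay reaches only the limit > 100000 nM, so no number is known for it. Going by the values given here, the single measured step, an at least 4.0-fold higher number from compound 1 to compound 2 (0.60 log units; beyond the scatter), rests on the limit of > 100000 nM in this assay, at which 1 of the 2 values shown sits, and does not touch the change considered here. Compound 3 `Cc1ccc(-c2cn(C[C@H](O)[C@H]3OC(=O)C(OCc4ccccc4)=C3OCc3ccccc3)nn2)cc1` differs from compound 2 by 4-methylphenyl in place of 2-methoxyphenyl on an aromatic carbon. Among the compounds with values here, no measured step compares two aryl groups at that aromatic carbon, so compound 3 is expected to stay close to the limit. The expectation for compound 3 is the estimated step of a number no higher from compound 2 to compound 3 (the limit leaves the size open), with an estimated value of 100000 nM and a range from 30000 nM to 300000 nM.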

Compound 3, half-maximal inhibitory concentration: 8770 nM
Compound 3: the middle estimate sits 11-fold (1.06 log units) above what was measured; measured number outside the range, below it.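

In this assay, this aromatic carbon responds to the choice between two aryl groups: 4-methylphenyl in place of 2-methoxyphenyl gives an at least 11-fold lower number from compound 2 to compound 3 (1.05 log units; beyond the scatter). On these data alone, the value of compound 2 is only a limit, so the size of that step stays open: the limit of > 100000 nM in this assay, at which 1 of the 3 values shown sits. An aryl group on this carbon is also not a loss in itself, as 4-methylphenyl in place of (((4-methylphenyl)sulfonyl)amino)methyl gives a 2.8-fold lower number from compound 1 to compound 3 (0.45 log units; beyond the scatter).

The compounds shown do not separate the methoxy group from its place on the ring, so it stays open how 2-methylphenyl or 4-methoxyphenyl would read. As far as these compounds go, how an amine or a carboxylic acid on this carbon would read also stays open.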